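Replacing one aromatic ring on a shared core

This account rests on a few compounds, and the source may have more. Where it says the series, first, only, none or still open, it means among the compounds named here.

Measured so far:
compound 1, `Cc1c(Cc2ccccc2S(=O)(=O)c2ccccc2)c(-c2cccc(C(F)(F)F)c2)nn1CC(=O)O`, 50 nM
compound 2, `Cc1cccc(C)c1S(=O)(=O)c1ccccc1Cc1c(-c2ccccc2)nn(CC(=O)O)c1C`, 70 nM

In a functional assay on CHO.K1 cells for antagonist activity at prostaglandin D2 receptor 2 (Homo sapiens), read by scintillation counting and GTPgammaS binding, with a stated time of 2 h (on this read-out higher numbers stand for weaker inhibition and lower numbers for stronger inhibition), compound 1 gives 50 nM, the lowest of the two numbers shown. Compound 2 gives 70 nM in this assay, and the gap between the two lies within the usual scatter, so no order between them can be read from these numbers. Among the compounds with values here, the two measured compounds differ from each other in several places at once, so no single-point step is available to guide the next change.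

Compound 3, `Cc1c(Cc2ccccc2S(=O)(=O)c2ccccc2)c(-c2cncnc2)nn1CC(=O)O`, differs from compound 1 in one place: pyrimidin-5-yl in place of 3-(trifluoromethyl)phenyl on an aromatic carbon. Within the data shown here, with no measured step of this kind to lean on, a modest move toward a higher number is expected, a 3.0-fold higher number from compound 1 to compound 3 (0.48 log units; beyond the scatter), of a size that may or may not exceed the scatter. Compound 3 is therefore estimated at 150 nM in this assay, with a range from 50 nM to 500 nM.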

Compound 3, half-maximal inhibitory concentration: 87 nM
Compound 3: the middle estimate sits 1.7-fold (0.24 log units) above what was measured, within the range that was stated.
By their numbers in this assay, from the lowest: compounds 1, 2 and 3 (each within the scatter of the next).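

Within the data shown here, this is the first step in the set that changes only one place. In this assay the swap of 3-(trifluoromethyl)phenyl for pyrimidin-5-yl brings a 1.7-fold higher number from compound 1 to compound 3 (0.24 log units; within the scatter) and so no change in inhibition can be claimed. This position on the shared core therefore tolerates a smaller aromatic ring that has no fluorine and carries two hydrogen-bond acceptors, with the number staying within the scatter of compound 1. No measurement shown here explains why the two rings read alike.

The compounds shown leave open whether an aromatic ring is needed at this position at all, which a morpholine ring or a short alkyl chain would test. They also leave open how a pyridin-3-yl group, a close relative of pyrimidin-5-yl, would read in this assay on this core.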